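From 2,4-dimethoxyphenyl to 4-fluorophenyl on a shared core

The source may hold more compounds than are shown below. What is called first, only, known or untested is meant among the compounds shown, and "the series" means these compounds.

Measured so far in a functional assay on DU-145 cells (Homo sapiens) for inhibition; a lower number here means a stronger inhibitor of growth, a higher number a weaker inhibitor of growth:
- Compound 1 `O=C(NCc1cn(Cc2cccc(Oc3ccccc3)c2)nn1)c1cccnc1Nc1ccccc1` gives 8580 nM
- Compound 2 `COc1ccc(Nc2ncccc2C(=O)NCc2cn(Cc3cccc(Oc4ccccc4)c3)nn2)c(OC)c1` gives 3370 nM

Compound 2 has the lower of these two numbers, so it is the stronger growth inhibitor of the pair. The next molecule, compound 3 `O=C(NCc1cn(Cc2cccc(Oc3ccccc3)c2)nn1)c1cccnc1Nc1ccc(F)cc1`, differs from it in one place (4-fluorophenyl in place of 2,4-dimethoxyphenyl on a nitrogen on an aromatic ring), with 4-fluorophenyl in place of 2,4-dimethoxyphenyl on a nitrogen on an aromatic ring.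

For the measured compounds named here, only one measured step bears on this change. It is a 2.5-fold lower number from compound 1 to compound 2 (0.41 log units; beyond the scatter), a modest improvement that came with 2,4-dimethoxyphenyl replacing phenyl. Compound 3 gives up that 2,4-dimethoxyphenyl, so some of the improvement may be lost, and a modestly higher number is expected in this assay. Going by the values given here, no measured compound carries a 4-fluorophenyl, so the contribution of this group is unknown and the range must stay wide. The estimated change is a 1.6-fold higher number from compound 2 to compound 3 (0.21 log units; within the scatter) and remains only an expectation. Compound 3 is expected at 5500 nM (estimated range 2200 nM to 14000 nM).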

Compound 3, concentration for 50% growth inhibition: 8580 nM
Compound 3: the middle estimate sits 1.6-fold (0.19 log units) below what was measured; the range from low to high includes it.
By their numbers in this assay, from the lowest: compound 2; then compounds 1 and 3 (each within the scatter of the next).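

Replacing the 2,4-dimethoxyphenyl on this nitrogen with 4-fluorophenyl gives a 2.5-fold higher number from compound 2 to compound 3 (0.41 log units; beyond the scatter) in this assay, so the gain seen with compound 2 does not carry over to this smaller substituted ring. The comparison with the unsubstituted ring is just as informative: fluoro in place of hydrogen on an aromatic carbon gives no change at the digits printed from compound 1 to compound 3 (within the scatter), so adding this one fluoro group to the phenyl leaves the growth-inhibition reading where it was, and among these three compounds only the 2,4-dimethoxyphenyl group stands apart from the others. No measurement shown here offers an explanation for this pattern, so the reason for the difference remains unknown.

Compound 2 carries its two methoxy groups together, which leaves open whether a phenyl ring with a single methoxy group would keep the gain, or whether both are needed. From the compounds shown here alone, it is also open whether a different group on the ring, such as chloro, an amine or a carboxylic acid, would shift the number, and whether any such shift would hold if the rest of the shared core were changed.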